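The source may report more compounds than this note shows. Statements on the series, on what has been measured and on what is new or still open speak of the compounds shown alone.

Measured so far in a functional assay on DU-145 cells (Homo sapiens) for inhibition, read by trypan blue exclusion, with a stated time of 96 h; on this read-out higher numbers stand for weaker inhibition of growth and lower numbers for stronger inhibition of growth:
- compound 1 `O=C(/C(=C\c1ccc(Br)cc1)SCc1ccc(Cl)cc1)c1ccc(Br)cc1`: 1000 nM
- compound 2 `O=C(/C(=C\c1ccc(Br)cc1)Sc1ccc(Br)cc1)c1ccc(Br)cc1`: 1000 nM
- compound 3 `COc1ccc(S/C(=C/c2ccc(Br)cc2)C(=O)c2ccc(Br)cc2)cc1`: 20000 nM

Compound 2 shares the lowest number of the three with compound 1. The next analogue is compound 4 `COc1ccc(/C=C(/Sc2ccc(Br)cc2)C(=O)c2ccc(Br)cc2)c(F)c1`, not yet measured, and the change from compound 2 is 2-fluoro-4-methoxyphenyl in place of 4-bromophenyl on a double-bonded chain carbon bound to a double-bonded chain carbon.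

Among the compounds with values here, no measured step touches this place, as all three compounds carry 4-bromophenyl there. The steps available concern the group on sulfur. no change at the digits printed from compound 1 to compound 2 (within the scatter) lies within the scatter, while a 20-fold higher number from compound 1 to compound 3 (1.30 log units; beyond the scatter) is large. Within the data shown here, the closest precedent is a 20-fold higher number from compound 2 to compound 3 (1.30 log units; beyond the scatter), also large, where methoxy replaces bromo on an aromatic carbon, though on the sulfur-bound group rather than at the site changed here. The expectation therefore borrows the direction of that step, but only part of its size, given the different site.

In this assay, the expected shift is a 3.0-fold higher number from compound 2 to compound 4 (0.48 log units; beyond the scatter). For compound 4 the estimated value is 3000 nM, with an expected range of 600 nM to 15000 nM.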

Compound 4, concentration for 50% growth inhibition: 20000 nM
Beside the measured number, compound 4's estimate is 6.7-fold (0.82 log units) below it; measured number outside the range, above it.
By their numbers in this assay, from the lowest: compounds 1 and 2 (each within the scatter of the next); then compounds 3 and 4 (each within the scatter of the next).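

In this assay, within the data shown here, the place on a double-bonded chain carbon bound to a double-bonded chain carbon, held by 4-bromophenyl in all the earlier compounds, proves sensitive to change: 2-fluoro-4-methoxyphenyl there gives a 20-fold higher number from compound 2 to compound 4 (1.30 log units; beyond the scatter). The step is as large as a 20-fold higher number from compound 2 to compound 3 (1.30 log units; beyond the scatter), where methoxy replaces bromo on the sulfur-bound group, so in compound 2 neither this place nor that one tolerates the exchange made. No measurement at hand explains the result.

The change removes bromo and brings in fluoro and methoxy at once, so the compounds shown cannot assign the step to any one of these. Also open, from the compounds shown here alone, is whether 4-chlorophenyl, or a phenyl ring carrying an amine or a carboxylic acid, would hold the growth inhibition of compound 2 at this place.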